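Compound 4: a Different Phenyl After a Limit

This account rests on a few compounds, and the source may have more. Where it says the series, first, only, none or still open, it means among the compounds named here.

compound 1 `Cc1ccnc(NC(c2ccccc2F)c2ccc3cccnc3c2O)c1`: 880 nM
compound 2 `COc1cccc(C(Nc2ccccn2)c2ccc3cccnc3c2O)c1`: 2860 nM
compound 3 `Cc1ccnc(NC(c2ccccc2C)c2ccc3cccnc3c2O)c1`: > 40000 nM

In an assay for inhibition of protein disulfide-isomerase (Homo sapiens), with a stated time of 1 h (on this read-out higher numbers stand for weaker inhibition and lower numbers for stronger inhibition), compound 1 gives 880 nM. Compound 2 gives 2860 nM in this assay. For compound 3 only a limit of the assay is known in this assay, namely > 40000 nM. Among the measured compounds shown here, compound 3 is thus the one value that sits at the limit of > 40000 nM in this assay, at which 1 of the 3 values shown sits, and no number for it exists among the measured results. For the measured compounds named here, the single measured step that bears on compound 3 is an at least 45-fold higher number from compound 1 to compound 3 (1.65 log units; beyond the scatter), a large change on the phenyl carried by the chain carbon.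

Compound 4 `CCc1ccc(C(Nc2cc(C)ccn2)c2ccc3cccnc3c2O)cc1` differs from compound 3 by 4-ethylphenyl in place of 2-methylphenyl on a saturated chain carbon bound to an aromatic carbon and a nitrogen on an aromatic ring. Going by the values given here, the 2-methylphenyl that accompanied the limit leaves, and a 4-ethylphenyl enters, for which no measured compound offers a direct comparison; compound 1 and compound 2 carry fluoro and methoxy on their phenyls, and neither carries an ethyl. With compound 3 at a limit, the step of an at least 6.6-fold lower number from compound 3 to compound 4 (0.82 log units; beyond the scatter) can only be expected roughly, toward a lower number. Compound 4 is estimated at 6000 nM in this assay, with a range from 900 nM to 40000 nM.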

Compound 4, half-maximal inhibitory concentration: 5390 nM
The estimate for compound 4 lay 1.1-fold (0.05 log units) above the measured number, within the range that was stated.
By their numbers in this assay, from the lowest: compound 1; then compounds 2 and 4 (each within the scatter of the next). At a limit, above all of these: compound 3.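

In this assay, 4-ethylphenyl in place of 2-methylphenyl on the chain carbon brings an at least 7.4-fold lower number from compound 3 to compound 4 (0.87 log units; beyond the scatter), so a phenyl carrying a carbon chain does not in itself put a compound at the limit. The value of compound 3 remains a limit of the assay and not a number: the limit of > 40000 nM in this assay, at which 1 of the 4 values shown sits. Even so, 4-ethylphenyl does not match 2-fluorophenyl at this position, with a 6.1-fold higher number from compound 1 to compound 4 (0.79 log units; beyond the scatter).

What stays open is how much of the step from 2-methylphenyl to 4-ethylphenyl belongs to the place of the group on the ring and how much to methyl versus ethyl, as neither 4-methylphenyl nor 2-ethylphenyl stands among these compounds. Also open, as far as these compounds go, is how a longer chain such as 4-propylphenyl, or a phenyl bearing an amine or a carboxylic acid, would read here.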